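The source may hold more compounds than are shown below. What is called first, only, known or untested is meant among the compounds shown, and "the series" means these compounds.

Four close relatives of one shared core are compared here in a functional assay on HEp-2 cells (Homo sapiens) for inhibition; a higher number here means a weaker inhibitor, a lower number a stronger inhibitor. Compound 1, `CC(=O)OC(C)n1cnc2c(Cl)nc(I)nc21`, gives 6310 nM. Compound 2, `CC(O)n1cnc2c(Cl)nc(I)nc21`, reaches only the limit of the measurement, > 500000 nM. Compound 3, `CC(O)n1cnc2c(N)nc(I)nc21`, likewise reaches only the limit, > 500000 nM. Compound 4, `CC(=O)OC(C)n1cnc2c(N)nc(I)nc21`, has not yet been measured.

The change from compound 2 to compound 1 is acetyl in place of hydrogen on an oxygen on a saturated carbon; it produces an at least 79-fold lower number from compound 2 to compound 1 (1.89 log units; beyond the scatter). Compound 2 and compound 3 differ in their cores: amino in place of chloro on an aromatic carbon. Because both sit at the limit of > 500000 nM in this assay, at which 2 of the 3 values shown sit, that step is a step that the two limits leave unreadable from compound 2 to compound 3.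

Compound 4 carries the same change relative to compound 3: acetyl in place of hydrogen on an oxygen on a saturated carbon, at a place described in the same words as for compound 1. The step from compound 3 to compound 4 is expected to be an at least 41-fold lower number from compound 3 to compound 4 (1.61 log units; beyond the scatter), resting on the step of an at least 79-fold lower number from compound 2 to compound 1 (1.89 log units; beyond the scatter) and on compound 1 giving 6310 nM, while the unknown weight of the core difference amino in place of chloro on an aromatic carbon widens the range. Compound 4 is therefore estimated at 12000 nM, between 1500 nM and 200000 nM.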

Compound 4, half-maximal inhibitory concentration: > 500000 nM
Compound 4 was reported as a limit (the forecaster's own chance of this, stated with the estimate: 25%); middle value at least 41-fold (1.61 log units) away from the limit.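

In this assay compound 4 gives > 500000 nM as a limit of the measurement, not a number. With the acetyl kept in place, amino in place of chloro on an aromatic carbon gives an at least 79-fold higher number from compound 1 to compound 4 (1.89 log units; beyond the scatter) and so the readable value seen with acetyl on the core of compound 1 does not carry over to the amino core. This does not show that acetyl does nothing on the amino core, and neither the step from compound 3 to compound 4 nor the step from compound 2 to compound 3 can be read, because both ends of each step stand at the same limit: the limit of > 500000 nM in this assay, at which 3 of the 4 values shown sit.

The compounds shown leave open whether another group on that oxygen, such as propionyl or benzoyl, would give a readable value on the amino core. They also leave open how a group other than chloro or amino on that aromatic carbon, such as methoxy or methylamino, would behave with the acetyl in place.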